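Replacing the dichlorophenyl arm of compound 3

This account rests on a few compounds, and the source may have more. Where it says the series, first, only, none or still open, it means among the compounds named here.

Compound 1 `CCCS(=O)(=O)Nc1ccc(F)c(C(=O)c2n[nH]c3ncc(-c4ccccc4F)cc23)c1F`: 2%
Compound 2 `CCCS(=O)(=O)Nc1ccc(F)c(C(=O)c2n[nH]c3ncc(-c4ccc(O)cc4)cc23)c1F`: 0.75%
Compound 3 `CCCS(=O)(=O)Nc1ccc(F)c(C(=O)c2n[nH]c3ncc(-c4ccc(Cl)cc4Cl)cc23)c1F`: 22%

All three were measured in an assay for binding affinity to dual specificity mitogen-activated protein kinase kinase 4 (Homo sapiens), read by KINOMEscan, tested at 100 nM; on this read-out higher numbers stand for a weaker effect at the one concentration tested and lower numbers for a stronger effect. Compound 3 stands highest of the three numbers: the step of a number 20 percentage points higher from compound 1 to compound 3 (beyond the scatter) and the step of a number 21.3 percentage points higher from compound 2 to compound 3 (beyond the scatter) both run beyond the scatter, whereas a number 1.3 percentage points lower from compound 1 to compound 2 (within the scatter) stays within it. Compound 4 `CCCS(=O)(=O)Nc1ccc(F)c(C(=O)c2n[nH]c3ncc(-c4ccc(Cl)c(C(F)(F)F)c4)cc23)c1F` has not yet been measured. It differs from compound 3 in one place: 4-chloro-3-(trifluoromethyl)phenyl in place of 2,4-dichlorophenyl on an aromatic carbon. Among the measured compounds shown here, no measured step exchanges one halogenated aryl for another, so none bears on this change directly; the two steps that reach compound 3 altered the same aryl and each moved the read-out modestly, showing that this position matters. With no closer guide, compound 4 is expected to show a number 7 percentage points lower from compound 3 to compound 4 (within the scatter) in this assay, an estimated 15% with a range from 2% to 45%.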

Compound 4, a percentage reported as activity, at one concentration (the size of the read-out at that concentration, not a potency): 15%
Compound 4: the middle estimate sits on the measured number at the digits printed; low and high end bracket the measured number.
By their numbers in this assay, from the lowest: compounds 2 and 1 (each within the scatter of the next); then compounds 4 and 3 (each within the scatter of the next).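

In this assay exchanging one chlorine-bearing aryl for another gives a number 7 percentage points lower from compound 3 to compound 4 (within the scatter), so this position tolerates 4-chloro-3-(trifluoromethyl)phenyl as well as 2,4-dichlorophenyl without a change beyond the scatter. The new arm still stands apart from 4-hydroxyphenyl and 2-fluorophenyl, with a number 14.3 percentage points higher from compound 2 to compound 4 (beyond the scatter) and a number 13 percentage points higher from compound 1 to compound 4 (beyond the scatter), which places both chlorine-bearing arms together on the weaker side of the series. Nothing available explains this grouping. On these data alone, it remains open whether an amine or a carboxylic acid on this phenyl ring would match compound 2, and whether chlorine itself matters.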